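The source may report more compounds than this note shows. Statements on the series, on what has been measured and on what is new or still open speak of the compounds shown alone.

Measured so far in an assay for inhibition of serine/threonine-protein kinase Sgk1 (Homo sapiens), with stated times of 30 min and 60 min, in the presence of a further agent that is not named here; a higher number here means a weaker inhibitor, a lower number a stronger inhibitor:
compound 1 `Cc1n[nH]c2nc(-c3ccc(NS(=O)(=O)c4cc(Cl)ccc4F)cc3)nc(OCC(CO)CO)c12`: 1 nM
compound 2 `Cc1n[nH]c2nc(-c3ccc(NS(=O)(=O)c4cc(Cl)ccc4F)cc3)nc(OC3CCOCC3)c12`: 5 nM

Within the data shown here, compound 2 stands at the higher of the two numbers; the only measured step is a 5.0-fold higher number from compound 1 to compound 2 (0.70 log units; beyond the scatter), so compound 2 is the weaker of the pair in this assay.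

Compound 3 `Cc1n[nH]c2nc(-c3ccc(NS(=O)(=O)c4cc(Cl)ccc4F)cc3)nc(OC3CCC(=O)CC3)c12` differs from compound 2 by 4-oxocyclohexyl in place of oxan-4-yl on an oxygen on an aromatic ring. Among the measured compounds shown here, no measured step covers this exchange; the step from the open chain to the ring, a 5.0-fold higher number from compound 1 to compound 2 (0.70 log units; beyond the scatter), concerns a different change on the same oxygen and gives no direction here. Expected for compound 3, therefore: no step beyond the scatter, no change at the digits printed from compound 2 to compound 3 (within the scatter). The estimate for compound 3 in this assay is 5 nM, range 2 nM to 15 nM.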

Compound 3, half-maximal inhibitory concentration: 5 nM
Estimate against measurement, compound 3: no gap at the digits printed; the measured number falls inside the stated range.
By their numbers in this assay, from the lowest: compound 1; then compounds 2 and 3 (each within the scatter of the next).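

On the oxygen on an aromatic ring in this assay, the exchange of oxan-4-yl for 4-oxocyclohexyl gives no change at the digits printed from compound 2 to compound 3 (within the scatter) and so replaces a ring with one hetero atom by a ring of carbon only without a readable effect. Against the open chain, the second ring shows a 5.0-fold higher number from compound 1 to compound 3 (0.70 log units; beyond the scatter) as well, matching the gap already seen for oxan-4-yl. Nothing available explains either step. Open, on these data alone, is whether a 4-aminocyclohexyl or 4-carboxycyclohexyl group would stay within the scatter of compounds 2 and 3. Also open, as far as these compounds go, is whether a shorter 2-hydroxyethyl chain would come closer to compound 1.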